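A Glycine Ester Amide in Place of Methyl: One Untested Step

A few compounds are considered here, and "the series" means these few. Any claim that something is new, unique, unknown or untested is made for them only; others in the source may bear on it.

Compound 1 `Cc1ccc(-n2ncc3c(N)ncnc32)cc1` is the reference point, though it has no measurement to stand on. In a functional assay on NCI-H460 cells (Homo sapiens) for inhibition, with a stated time of 48 h (a higher number here means a weaker inhibitor of growth, a lower number a stronger inhibitor of growth), compound 1 gives "not determined" (no result reported), so no number is available for it at all. For the measured compounds named here, the only other compound measured, compound 2 `N#Cc1cnn(-c2ccc(C(F)(F)F)cc2)c1N`, returns a limit of the assay rather than a number in this assay. Compound 2 gives > 150000 nM, and this is a limit only. That single limit is the one fixed point in the data, as the limit of > 150000 nM in this assay, at which 1 of the 2 values shown sits, shows.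

Compound 3 `COC(=O)CNC(=O)c1ccc(-n2ncc3c(N)ncnc32)cc1` is the compound now awaiting a result. It differs from compound 1 in one place: ((methoxycarbonyl)methyl)carbamoyl in place of methyl on an aromatic carbon. Going by the values given here, no pair of measured compounds differing in one place exists here, so the size of the step from compound 1 to compound 3 in this assay cannot be read from any matched comparison, and no direction beyond the usual scatter is anticipated on this evidence. With only a limit to guide the guess, compound 3 is expected to give about 30000 nM in this assay, with a range from 3000 nM to 150000 nM.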

Compound 3, concentration for 50% growth inhibition: > 150000 nM
Compound 3: a limit, no number; the forecaster's own chance of this, stated with the estimate: 45%; middle value at least 5.0-fold (0.69 log units) away from the limit.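

In this assay compound 3 gives > 150000 nM, which is a limit and not a number. For the compounds shown here, compound 1 has no number there either, so no step from compound 1 to compound 3 can be read. The compounds shown leave open whether ((methoxycarbonyl)methyl)carbamoyl in place of methyl changes growth inhibition in this assay at all.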